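Phenyl carbamate replacing hexyl on a selenocyanate core

A few compounds are considered here, and "the series" means these few. Any claim that something is new, unique, unknown or untested is made for them only; others in the source may bear on it.

Of the compounds shown here, three have been measured in a physicochemical assay, with a stated time of 180 min, tested at 0.5 mg/mL; on this read-out lower numbers stand for less inhibition and higher numbers for more inhibition at the one concentration tested (going by the name of the read-out). Compound 1 `CC(C)COC(=O)Nc1ccc([Se]C#N)cc1` carries an isobutyl carbamate on the shared core; in this assay compound 1 gives 27.1%. Compound 2 `Cc1ccc(OC(=O)Nc2ccc([Se][Se]c3ccc(NC(=O)Oc4ccc(C)cc4)cc3)cc2)cc1` is a diselenide dimer with tolyl carbamates; in this assay compound 2 gives > 50%, which is a limit of the assay and not a number. Compound 3 `CCCCCCOC(=O)Nc1ccc([Se]C#N)cc1` is the hexyl carbamate of the same core as compound 1; in this assay compound 3 gives > 25%, again a limit of the assay rather than a number. The step that the limit leaves unreadable from compound 1 to compound 3 therefore cannot be read, as the limit of > 25% in this assay, at which 1 of the 3 values shown sits, shows, and the limit of > 50% in this assay, at which 1 of the 3 values shown sits, likewise leaves the value of compound 2 open.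

Compound 4 `N#C[Se]c1ccc(NC(=O)Oc2ccccc2)cc1` differs from compound 3 by phenyl in place of hexyl on an oxygen next to a carbonyl group. Among the compounds with values here, no measured step exchanges a chain for a ring on an oxygen next to a carbonyl group, so nothing among the measured steps bears directly on this change; compound 2 and compound 3 both sit at limits and cannot be compared. The expected step that the limit leaves unreadable from compound 3 to compound 4 is thus small, with wide uncertainty. Compound 4 is expected to give about 35%, within a range from 15% to 60%.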

Compound 4, a percentage reported as inhibition, at one concentration (the size of the read-out at that concentration, not a potency): 19.3%
Estimate against measurement, compound 4: 15.7 percentage points above; the range from low to high includes it.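

Within the data shown here, compound 4 gives the first readable number in this assay for a ring, phenyl, on an oxygen next to a carbonyl group of the shared core. Phenyl in place of isobutyl is a number 7.8 percentage points lower from compound 1 to compound 4 (within the scatter) and so shows no clear effect of exchanging this chain for this ring, while phenyl in place of hexyl is a number at least 5.7 percentage points lower from compound 3 to compound 4 (that floor lies within the scatter) and so leaves open a larger drop than the scatter allows. From the compounds shown here alone, the true size of that second step stays unknown because compound 3 carries a limit of the assay and not a number: the limit of > 25% in this assay, at which 1 of the 4 values shown sits.

The step from compound 1 to compound 3 still cannot be read, and compound 2, a diselenide dimer that differs from the others in more than one place, offers no clean comparison. Going by these compounds, it remains open whether a longer chain on this oxygen, or an amine or a carboxylic acid on the phenyl ring, would move the read-out beyond the usual scatter.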